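Compound 3 to Compound 4: 4-Methoxyphenyl to Phenyl

The source may report more compounds than this note shows. Statements on the series, on what has been measured and on what is new or still open speak of the compounds shown alone.

In a functional assay on HCT-116 cells (Homo sapiens) for inhibition, read by sulforhodamine B assay, with a stated time of 48 h, tested at 50 uM (on this read-out lower numbers stand for less inhibition of growth and higher numbers for more inhibition of growth at the one concentration tested), compound 3 (`COc1ccc(/C=C/C(=O)/C=C/c2ccc(OCc3cn(CCCCCOc4cc(=O)oc5ccccc45)nn3)c(OC)c2)cc1`) gives 35% and sits within the scatter of both other measured compounds: compound 1 (`COc1cccc(/C=C/C(=O)/C=C/c2ccc(OCc3cn(CCCCCOc4cc(=O)oc5ccccc45)nn3)c(OC)c2)c1`) gives 36% and compound 2 (`COc1cc(/C=C/C(=O)/C=C/c2cccs2)ccc1OCc1cn(CCCCCOc2cc(=O)oc3ccccc23)nn1`) gives 31% there. Compound 4 (`COc1cc(/C=C/C(=O)/C=C/c2ccccc2)ccc1OCc1cn(CCCCCOc2cc(=O)oc3ccccc23)nn1`) carries phenyl where compound 3 carries 4-methoxyphenyl, with hydrogen in place of methoxy on an aromatic carbon, para to a large group (hydrogen in place of methoxy on an aromatic carbon). Three measured swaps of this same group bear on it: one gives a number 1 percentage points lower from compound 1 to compound 3 (within the scatter) and another a number 5 percentage points lower from compound 1 to compound 2 (within the scatter) and the third a number 4 percentage points higher from compound 2 to compound 3 (within the scatter) and none leaves the scatter. Plain phenyl itself has not yet been measured. A step of a number 2 percentage points lower from compound 3 to compound 4 (within the scatter) is therefore expected, which is nothing beyond the scatter. Compound 4 is estimated at 33% with an expected range from 24% to 42% in this assay for now.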

Compound 4, percent growth inhibition at one concentration: 24%
The estimate for compound 4 lay 9 percentage points above the measured number; the measured number falls inside the stated range.
By their numbers in this assay, from the lowest: compounds 4, 2, 3 and 1 (each within the scatter of the next, the first and the last beyond it).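

In this assay, going by these compounds alone, the swaps among 3-methoxyphenyl, 4-methoxyphenyl and thiophen-2-yl had all stayed within the scatter, but losing the methoxy altogether gives a number 11 percentage points lower from compound 3 to compound 4 (beyond the scatter) and also a number 12 percentage points lower from compound 1 to compound 4 (beyond the scatter), the first steps at this position to leave it. Thiophen-2-yl does not separate from phenyl, with a number 7 percentage points lower from compound 2 to compound 4 (within the scatter), so only the two methoxyphenyl compounds stand apart from compound 4. No measurement here accounts for this difference. Open, on these data alone, is whether a hydroxyl, a fluorine or a dimethylamino group on the same ring would keep the number near that of compound 3.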